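From 2-chlorophenyl to 3-chlorophenyl in compound 4

The source may hold more compounds than are shown below. What is called first, only, known or untested is meant among the compounds shown, and "the series" means these compounds.

Measured in a functional assay on K562 cells (Homo sapiens) for cytotoxicity, read by sulforhodamine B assay (on this read-out higher numbers stand for weaker inhibition of growth and lower numbers for stronger inhibition of growth), so far:
- compound 1 `CC1=CC[C@@H]([C@@](C)(O)CCCC(C)(C)NC(=S)N/N=C\c2ccccc2)CC1` gives 130 nM
- compound 2 `CC1=CC[C@@H]([C@@](C)(O)CCCC(C)(C)NC(=S)N/N=C\c2ccc(C)cc2)CC1` gives 140 nM
- compound 3 `CC1=CC[C@@H]([C@@](C)(O)CCCC(C)(C)NC(=S)N/N=C\c2ccccc2Cl)CC1` gives 150 nM

Compound 3 sits level with the other two compounds (a 1.2-fold higher number from compound 1 to compound 3 (0.06 log units; within the scatter); a 1.1-fold higher number from compound 2 to compound 3 (0.03 log units; within the scatter)). Compound 4 `CC1=CC[C@@H]([C@@](C)(O)CCCC(C)(C)NC(=S)N/N=C\c2cccc(Cl)c2)CC1` carries 3-chlorophenyl in place of 2-chlorophenyl on a carbon with a double bond to nitrogen. For the measured compounds named here, no measured step makes this exact swap, so the evidence is indirect. Among these three compounds, adding a group to the aromatic ring has changed little: chloro gave the step above, and methyl gave a similar one (a 1.1-fold higher number from compound 1 to compound 2 (0.03 log units; within the scatter)). No step beyond the scatter is therefore expected in this assay, and the estimated change is small (a 1.1-fold lower number from compound 3 to compound 4 (0.03 log units; within the scatter)). For compound 4 the expected value is 140 nM with an estimated range from 80 nM to 250 nM on repeat measurement.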

Compound 4, concentration for 50% growth inhibition: 30 nM
The estimate for compound 4 lay 4.7-fold (0.67 log units) above the measured number, outside the stated range (below it).
By their numbers in this assay, from the lowest: compound 4; then compounds 1, 2 and 3 (each within the scatter of the next).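

In this assay, the place of the chlorine on the ring matters: 3-chlorophenyl in place of 2-chlorophenyl gives a 5.0-fold lower number from compound 3 to compound 4 (0.70 log units; beyond the scatter), although the two compounds have the same atoms. Compound 4 also stands apart from the plain phenyl, with a 4.3-fold lower number from compound 1 to compound 4 (0.64 log units; beyond the scatter), and from 4-methylphenyl, with a 4.7-fold lower number from compound 2 to compound 4 (0.67 log units; beyond the scatter), so changing the ring can shift this read-out after all. Nothing measured here explains the gain.

Open, from the compounds shown here alone, is whether 4-chlorophenyl, 3-methylphenyl or 3-bromophenyl would match compound 4, and so whether the gain belongs to chloro itself or to any group placed there.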